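From pyridin-3-yl to pyridin-4-yl in compound 1

A few compounds are considered here, and "the series" means these few. Any claim that something is new, unique, unknown or untested is made for them only; others in the source may bear on it.

Compound 1 `O=C1/C(=C/c2cccnc2)CN(S(=O)(=O)c2ccccc2)C/C1=C\c1ccccc1F` gives 15300 nM
Compound 2 `O=C1/C(=C/c2cccnc2)CN(S(=O)(=O)c2ccc(F)cc2)C/C1=C\c1ccccc1F` gives 15600 nM
Compound 3 `O=C1/C(=C/c2cccnc2)CN(S(=O)(=O)c2ccc(Br)cc2)C/C1=C\c1ccccc1F` gives 14600 nM

In an ADME assay on L02 cells (Homo sapiens) for cytotoxicity, read by MTT assay, with a stated time of 24 h (a higher number here means a weaker inhibitor, a lower number a stronger inhibitor), compound 1 gives 15300 nM, a number that cannot be told apart from the other two, as all three lie within the normal scatter of repeated measurements. Compound 4 `O=C1/C(=C/c2ccncc2)CN(S(=O)(=O)c2ccccc2)C/C1=C\c1ccccc1F` keeps the core of compound 1 and carries one change: pyridin-4-yl in place of pyridin-3-yl on a double-bonded chain carbon bound to a double-bonded ring carbon. The two have the same atoms, joined differently, with pyridin-4-yl in place of pyridin-3-yl.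

Among the compounds with values here, no measured step touches this place, so the evidence is only indirect. The swaps made elsewhere on the molecule are small: a 1.0-fold higher number from compound 1 to compound 2 (0.01 log units; within the scatter), a 1.0-fold lower number from compound 1 to compound 3 (0.02 log units; within the scatter) and a 1.1-fold lower number from compound 2 to compound 3 (0.03 log units; within the scatter). All three stay within the scatter, and none of them tests a pyridine change. No step beyond the scatter is therefore expected, in either direction, though the range is kept wide.

The expected step is a 1.0-fold lower number from compound 1 to compound 4 (0.01 log units; within the scatter).

For compound 4 the estimated value is 15000 nM, with an expected range from 9000 nM to 25000 nM.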

Compound 4, half-maximal inhibitory concentration: 15900 nM
The estimate for compound 4 lay 1.1-fold (0.03 log units) below the measured number; the measured number falls inside the stated range.
By their numbers in this assay, from the lowest: compounds 3, 1, 2 and 4 (each within the scatter of the next).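

Within the data shown here, this is the first direct test of this position. In this assay, pyridin-4-yl in place of pyridin-3-yl on a double-bonded chain carbon bound to a double-bonded ring carbon gives a 1.0-fold higher number from compound 1 to compound 4 (0.02 log units; within the scatter), so the two pyridine forms cannot be told apart in this measurement. Like the fluoro and bromo swaps elsewhere on the molecule, this change stays within the scatter, and no measurement shown offers an explanation for the result.

The compounds shown leave open whether any group other than a pyridine at this place, such as a phenyl ring carrying an amine or a carboxylic acid, would give a clearly different number. They also leave open whether pyridin-4-yl and pyridin-3-yl would still match if the 2-fluorophenyl part of the core were replaced.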